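The source may report more compounds than this note shows. Statements on the series, on what has been measured and on what is new or still open speak of the compounds shown alone.

Working notes on the series.

Compound 3 `CC(=O)NS(=O)(=O)c1ccc(-n2nc(-c3ccccc3)cc2-c2cc(O)ccc2O)cc1` gives 100000 nM in a functional assay on cells (Cancer cell lines, Homo sapiens) for cytotoxicity, read by sulforhodamine B assay, with a stated time of 48 h; on this read-out lower numbers stand for stronger inhibition of growth and higher numbers for weaker inhibition of growth. Within the data shown here, it stands level with compound 2 `NS(=O)(=O)c1ccc(-n2nc(-c3ccccc3)cc2-c2cc(O)ccc2O)cc1`, which gives 100000 nM; these two are together the highest of the three numbers so far. Compound 1 `COc1ccc(OC)c(-c2cc(-c3ccccc3)nn2-c2ccc(S(=O)(=O)NC(C)=O)cc2)c1` gives 18200 nM, a lower number than either.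

Two measured steps lead into compound 3. a 5.5-fold higher number from compound 1 to compound 3 (0.74 log units; beyond the scatter). no change at the digits printed from compound 2 to compound 3 (within the scatter).

Compound 4 `CC(=O)NS(=O)(=O)c1ccc(-n2nc(-c3ccccc3)cc2C2=CC(=O)C=CC2=O)cc1` has not yet been measured. It differs from compound 3 by a group of 8 heavy atoms (6 carbon, 2 oxygen; one six-membered non-aromatic ring of carbon only) in place of a group of 8 heavy atoms (6 carbon, 2 oxygen; one six-membered aromatic ring of carbon only), on an aromatic carbon. Among the measured compounds shown here, no measured step bears directly on this change: neither of the two steps recorded replaces the aromatic ring at this position with a non-aromatic one. For the measured compounds named here, the only step at the same place, that from compound 1 to compound 3, changed substituents on the ring while keeping it aromatic, and it was modest. The step on the sulfonamide nitrogen is remote from the position changed here and was within the scatter. The expectation for compound 4 is therefore a broad one, leaning toward a lower number, estimated as a 2.5-fold lower number from compound 3 to compound 4 (0.40 log units; beyond the scatter). Compound 4 is expected to give 40000 nM, within a range of 8000 nM to 100000 nM.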

Compound 4, concentration for total growth inhibition: 100000 nM
Beside the measured number, compound 4's estimate is 2.5-fold (0.40 log units) below it; measured number inside the range.
By their numbers in this assay, from the lowest: compound 1; then compounds 2, 3 and 4 (each within the scatter of the next).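

Among these compounds, at this position on the five-membered aromatic ring, the earlier compounds only changed substituents on an aromatic ring, whereas compound 4 replaces that ring with a six-membered non-aromatic ring of carbon only, and in this assay this gives no change at the digits printed from compound 3 to compound 4 (within the scatter). Loss of the aromatic ring, together with a fall from 2 hydrogen-bond donors to 0, therefore leaves the number unmoved in this pair, while the comparison with the 2,5-dimethoxyphenyl group gives a 5.5-fold higher number from compound 1 to compound 4 (0.74 log units; beyond the scatter), matching in size a 5.5-fold higher number from compound 1 to compound 3 (0.74 log units; beyond the scatter), so among the three groups at this position only the 2,5-dimethoxyphenyl group stands apart. No available evidence accounts for this result.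

The compounds shown leave open whether any non-aromatic ring at this position can reach a number as low as that of the 2,5-dimethoxyphenyl group, since the only such ring here shares its number with the 2,5-dihydroxyphenyl group. They also leave open what an amine, a carboxylic acid or a longer alkoxy chain on the aromatic ring at this position would do to the number.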